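The compounds below may be only part of what the source reports. "The series", "measured", "known", "first", "only" and "open" are said of these compounds alone.

In an assay on membranes from Chem-1 cells for displacement of a labelled ligand from prostaglandin E2 receptor EP3 subtype (Homo sapiens), read by scintillation counting, with a stated time of 2 h (a lower number here means a stronger inhibitor, a higher number a weaker inhibitor), the measured compounds give:

Compound 1 `CC(C)C(CC1C(=O)NC(=O)N1C)c1ccc(-c2ccc3cccc(F)c3c2)[nH]c1=O`: 17 nM
Compound 2 `CCC(/C=C1\OC(=O)NC1=O)(CC)c1ccc(-c2ccc3cc(F)cc(F)c3c2)[nH]c1=O`: 28 nM
Compound 3 `CC(C)/C(=C1\C(=O)NC(=O)N1C)c1ccc(-c2ccc3cccc(F)c3c2)[nH]c1=O`: 85 nM

Compound 1 shows the lowest number of the three, although compound 2 sits within the usual scatter of it; only compound 3 stands clearly apart with a higher number. Compound 4 `CC(C)C(c1ccc(-c2ccc3cccc(F)c3c2)[nH]c1=O)C1C(=O)NC(=O)N1C` is not yet measured. It differs from compound 1 by 3-methyl-2,5-dioxoimidazolidin-4-yl in place of (3-methyl-2,5-dioxoimidazolidin-4-yl)methyl on a saturated chain carbon bound to an aromatic carbon and a saturated chain carbon, so the ring is joined directly to the chain carbon rather than through a single carbon. For the measured compounds named here, no measured pair shows this change alone. Compound 3, where the same ring is attached directly but through a double bond, gives a higher number than compound 1, so a modest shift toward weaker binding in this assay is expected for compound 4, though it may stay within the scatter. The estimate for compound 4 is 40 nM (range 15 nM to 120 nM), a step of a 2.4-fold higher number from compound 1 to compound 4 (0.37 log units; beyond the scatter) expected from compound 1.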

Compound 4, inhibition constant: 46 nM
Compound 4: middle estimate off by 1.2-fold (0.06 log units), on the low side, within the range that was stated.
By their numbers in this assay, from the lowest: compounds 1, 2, 4 and 3 (each within the scatter of the next, the first and the last beyond it).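

In this assay, for the compounds shown here, the 3-methyl-2,5-dioxoimidazolidin-4-yl ring joined directly to the saturated chain carbon, in place of the (3-methyl-2,5-dioxoimidazolidin-4-yl)methyl group, gives a modest loss (a 2.7-fold higher number from compound 1 to compound 4 (0.43 log units; beyond the scatter)), the only single change that can be read here. Shortening this link therefore weakens binding beyond the scatter but does not abolish it. Nothing available bears on the cause of this loss.

The compounds shown leave open how a longer chain carrying this ring would read in this assay and whether an amine or a carboxylic acid could stand in its place.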